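A few compounds are considered here, and "the series" means these few. Any claim that something is new, unique, unknown or untested is made for them only; others in the source may bear on it.

The compounds share one core, shown by compound 1 `C=CCn1c(=O)/c(=C\c2ccccc2Cl)[nH]c(=O)/c1=C\c1ccccc1OC`, and differ only in the ring attached to it. In a functional assay on MOLT-4 cells (Homo sapiens) for cytotoxicity, read by CCK-8 assay, with a stated time of 72 h (on this read-out lower numbers stand for stronger inhibition and higher numbers for weaker inhibition), compound 1 gives 4400 nM. Compound 2 `C=CCn1c(=O)/c(=C\c2ccc(Cl)c(Cl)c2)[nH]c(=O)/c1=C\c1ccccc1OC` carries a 3,4-dichlorophenyl ring in that position, and in this assay compound 2 is reported as "not active" (no number reported), with no number attached; it therefore stands as the weaker of the two measured compounds, though how far below compound 1 it falls cannot be read from a word alone. Compound 3 `C=CCn1c(=O)/c(=C\c2cccc(Br)c2)[nH]c(=O)/c1=C\c1ccccc1OC` is not yet measured and differs from compound 2 in one place: 3-bromophenyl in place of 3,4-dichlorophenyl on a double-bonded chain carbon bound to an aromatic carbon. Within the data shown here, since the two measured compounds give only one number and one non-numerical report, there is no measured step to lean on, and no cause can be assigned to the gap between them. Moving from a dichlorophenyl ring to a monobromophenyl ring returns the compound closer in size to compound 1, so a modest gain over compound 2 is the expected direction, with the real possibility that the result is again reported without a number. Compound 3 is expected to give about 9000 nM in this assay, within a range from 2500 nM to 40000 nM.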

Compound 3, half-maximal inhibitory concentration: 5000 nM
Compound 3: the middle estimate sits 1.8-fold (0.26 log units) above what was measured; measured number inside the range.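

Replacing 2-chlorophenyl with 3-bromophenyl on a double-bonded chain carbon bound to an aromatic carbon gives a 1.1-fold higher number from compound 1 to compound 3 (0.06 log units; within the scatter) in this assay, so these two rings cannot be told apart on this read-out. Compound 2, with its 3,4-dichlorophenyl ring, is reported as "not active" (no number reported) and compound 3, with its 3-bromophenyl ring, gives 5000 nM in the same assay, so a single change in this ring separates a report in words from a measured number, although the size of that gap cannot be read. Nothing measured here explains why these rings give these results.

All three rings shown at this position are phenyl rings carrying chlorine or bromine, so it remains open how a phenyl ring carrying an amine or a carboxylic acid would behave in this assay. A 3-chlorophenyl ring would also help to show whether the difference between compound 2 and compound 3 goes with the second chlorine or with the change of halogen.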